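The source may report more compounds than this note shows. Statements on the series, on what has been measured and on what is new or still open speak of the compounds shown alone.

Compound 1 `O=C1C(N2CCCCC2)=CC(=O)c2c1nc1n2[C@H]2OC[C@@H](O)[C@H]2OC1`: > 4000 nM
Compound 2 `COc1ccccc1NC1=CC(=O)c2nc3n(c2C1=O)[C@H]1OC[C@@H](O)[C@H]1OC3`: 1630 nM
Compound 3 `Cc1ccc(NC2=CC(=O)c3nc4n(c3C2=O)[C@H]2OC[C@@H](O)[C@H]2OC4)cc1`: 1420 nM

All three share one core and were tested in a functional assay on MGC-803 cells (Homo sapiens) for inhibition, read by sulforhodamine B assay; on this read-out higher numbers stand for weaker inhibition and lower numbers for stronger inhibition. Compound 1 gives > 4000 nM, which is a limit of the assay and not a number, so compound 1 stands at the limit of > 4000 nM in this assay, at which 1 of the 3 values shown sits. For the measured compounds named here, compound 2 and compound 3 carry an arylamino group and give numbers; the single measured step between them, a 1.1-fold lower number from compound 2 to compound 3 (0.06 log units; within the scatter), is small.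

Compound 4 `O=C1C(Nc2cccc(Cl)c2)=CC(=O)c2c1nc1n2[C@H]2OC[C@@H](O)[C@H]2OC1` differs from compound 1 by (3-chlorophenyl)amino in place of piperidin-1-yl on a double-bonded ring carbon. Going by the values given here, no measured step swaps piperidin-1-yl for an arylamino group, so the expectation rests on compound 2 and compound 3, whose values suggest compound 4 should fall in their region. A step downward from the limit is therefore expected, an at least 2.6-fold lower number from compound 1 to compound 4 (0.42 log units; beyond the scatter). Compound 4 is estimated at 1500 nM, likely between 600 nM and 4000 nM.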

Compound 4, half-maximal inhibitory concentration: 1530 nM
Estimate against measurement, compound 4: 1.0-fold (0.01 log units) below; low and high end bracket the measured number.
By their numbers in this assay, from the lowest: compounds 3, 4 and 2 (each within the scatter of the next). At a limit, above all of these: compound 1.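

For the compounds shown here, putting (3-chlorophenyl)amino in place of piperidin-1-yl on this double-bonded ring carbon gives an at least 2.6-fold lower number from compound 1 to compound 4 (0.41 log units; beyond the scatter) in this assay, the first step at this position that lies beyond the scatter. On these data alone, compound 1 stands at a limit and not a number, so the full size of this step stays unknown: the limit of > 4000 nM in this assay, at which 1 of the 4 values shown sits. Compound 4 lies within the scatter of compound 2 and compound 3, so these three arylamino compounds cannot be ranked.

Open, as far as these compounds go, is whether the step follows the amine hydrogen or the aromatic ring. A cyclohexylamino group, which keeps the hydrogen without the aromatic ring, would help to separate the two.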